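The source may hold more compounds than are shown below. What is called first, only, known or untested is meant among the compounds shown, and "the series" means these compounds.

Three compounds share one core and differ only in the group on a saturated chain carbon bound to a sulfur. Compound 1 `N#Cc1c(N)nc(SCC(N)=O)c(C#N)c1-c1ccc(OCC2CC2)cc1` carries a carbamoyl there, and in an assay on CHO cells for displacement of a labelled ligand from adenosine receptor A3 (Homo sapiens), read by scintillation counting, with a stated time of 120 min, tested at 1 uM (on this read-out lower numbers stand for less inhibition and higher numbers for more inhibition at the one concentration tested (going by the name of the read-out)), compound 1 gives 8%. Compound 2 `N#Cc1c(N)nc(SCc2ccn[nH]2)c(C#N)c1-c1ccc(OCC2CC2)cc1` carries a 1H-pyrazol-5-yl in its place, and in this assay compound 2 gives 6%. Compound 3 `N#Cc1c(N)nc(SCc2cccc(C(N)=O)c2)c(C#N)c1-c1ccc(OCC2CC2)cc1` carries a 3-carbamoylphenyl, and in this assay compound 3 gives 1%. Compound 1 has the highest of the three numbers, but the steps between them are small: a number 2 percentage points lower from compound 1 to compound 2 (within the scatter), a number 7 percentage points lower from compound 1 to compound 3 (within the scatter) and a number 5 percentage points lower from compound 2 to compound 3 (within the scatter), each within the scatter, so the three compounds cannot be told apart on this read-out.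

Compound 4 `CC(C)COc1ccc(-c2c(C#N)c(N)nc(SCC(N)=O)c2C#N)cc1` differs from compound 1 at a different place: isopropyl in place of cyclopropyl on a saturated chain carbon bound to an oxygen on an aromatic ring. Among the measured compounds shown here, none of the measured steps concerns that place; all three concern the group on a saturated chain carbon bound to a sulfur, and all three stayed within the scatter. For the measured compounds named here, there is thus nothing among the measured compounds to suggest a step beyond the scatter in this assay in either direction. Compound 4 is therefore expected to give 8%, within 0% to 22%. That estimate means no change at the digits printed from compound 1 to compound 4 (within the scatter), a step expected to stay within the scatter.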

Compound 4, a percentage reported as inhibition, at one concentration (the size of the read-out at that concentration, not a potency): 9%
Compound 4: middle estimate off by 1 percentage points, on the low side; the range from low to high includes it.
By their numbers in this assay, from the lowest: compounds 3, 2, 1 and 4 (each within the scatter of the next).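

Among the compounds shown here, the earlier compounds varied only the group on a saturated chain carbon bound to a sulfur, so compound 4 gives the first reading at a second place in the molecule, on a saturated chain carbon bound to an oxygen on an aromatic ring. There, isopropyl in place of cyclopropyl opens the three-membered ring while keeping the same 3 carbon heavy atoms, and in this assay this gives a number 1 percentage points higher from compound 1 to compound 4 (within the scatter) and leaves compound 1 and compound 4 impossible to tell apart, so on this read-out at one concentration the ring itself is not shown to matter. Nothing measured on these compounds says why the two read alike.

From the compounds shown here alone, both groups at this place are small and made of carbon alone, so it remains open whether an amine, a carboxylic acid or a longer chain such as n-hexyl there would give a step beyond the scatter. Also open, going by these compounds, is whether the same swap would read alike with a 1H-pyrazol-5-yl or a 3-carbamoylphenyl on the saturated chain carbon bound to a sulfur.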